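Aryl amide swap on a naphthylamine potassium channel series

The source may hold more compounds than are shown below. What is called first, only, known or untested is meant among the compounds shown, and "the series" means these compounds.

Compound 1 `CCC(=O)Nc1c(C(O)(C(F)(F)F)C(F)(F)F)ccc2ccccc12` gives 15 nM in an assay on LtK cells with ATP-sensitive inward rectifier potassium channel 11 (Homo sapiens) as the target; a lower number here means that less compound is needed, a higher number that more compound is needed for the effect. Compound 2 `Cc1ccccc1C(=O)Nc1c(C(O)(C(F)(F)F)C(F)(F)F)ccc2ccccc12` gives 5550 nM.

Compound 2 stands highest of the two measured numbers, its nearest neighbour being compound 1, with a 370-fold higher number from compound 1 to compound 2 (2.57 log units; beyond the scatter). Compound 3 `O=C(Nc1c(C(O)(C(F)(F)F)C(F)(F)F)ccc2ccccc12)c1cc(Cl)cc(Cl)c1` differs from compound 2 by 3,5-dichlorophenyl in place of 2-methylphenyl on a carbonyl carbon. For the measured compounds named here, no measured step compares one aryl group with another on this carbonyl carbon; the only step known leads from ethyl to an aryl group. Compound 3 is therefore expected to stay close to compound 2, with a 2.2-fold lower number from compound 2 to compound 3 (0.35 log units; beyond the scatter). Compound 3 is estimated at 2500 nM, within 300 nM to 12000 nM.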

Compound 3, half-maximal effective concentration: 306 nM
The estimate for compound 3 lay 8.2-fold (0.91 log units) above the measured number, within the range that was stated.
By their numbers in this assay, from the lowest: compound 1; then compound 3; then compound 2.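

In this assay the choice of aryl group on this carbonyl carbon carries real weight, with an 18-fold lower number from compound 2 to compound 3 (1.26 log units; beyond the scatter) when one aryl group replaces another, so having an aryl group there does not by itself set the number at the level of compound 2. Ethyl still gives the lowest number of the three, with a 20-fold higher number from compound 1 to compound 3 (1.31 log units; beyond the scatter) even for the lower-numbered of the two aryl groups. Nothing available explains either step.

The 2-methylphenyl and 3,5-dichlorophenyl groups differ in both their substituents and where these sit, so the compounds shown do not separate those two changes. On these data alone, how a cyclopropyl group, a longer alkyl chain or a pyridine ring would behave on this carbonyl carbon remains open.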